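This account rests on a few compounds, and the source may have more. Where it says the series, first, only, none or still open, it means among the compounds named here.

Compounds measured so far in a functional assay on ileum (Cavia porcellus) for inhibition of cysteinyl leukotriene receptor (Homo sapiens); on this read-out higher numbers stand for higher potency (the scale is a negative logarithm) and lower numbers for lower potency:

compound 1, `CCCc1c(OCCCCC(=O)O)ccc(C(C)=O)c1O`, with 5.8
compound 2, `CCCc1c(OCCCCCCCc2nn[nH]n2)ccc(C(C)=O)c1O`, with 7
compound 3, `CCCc1c(OCCCCCc2nn[nH]n2)ccc(C(C)=O)c1O`, with 6.6

Compound 3 stands second highest of the three numbers in this assay: compound 2 lies above it by a number 0.40 log units lower from compound 2 to compound 3 (beyond the scatter), and compound 1 lies below it by a number 0.80 log units higher from compound 1 to compound 3 (beyond the scatter). Both gaps are beyond the scatter.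

Compound 4, `CCCc1c(OCCCCCCC(=O)O)ccc(C(C)=O)c1O`, has not yet been measured in this assay. Its difference from compound 3 is carboxymethyl in place of 2H-tetrazol-5-yl on a saturated chain carbon, five bonds along the chain from an oxygen on an aromatic ring. Among the measured compounds shown here, two measured steps bear on this. The exchange of a carboxy group for a tetrazole on the same chain raised the number by a number 0.80 log units higher from compound 1 to compound 3 (beyond the scatter) and, with a longer linker, by a number 1.20 log units higher from compound 1 to compound 2 (beyond the scatter); compound 4 goes the other way, back to a carboxylic acid, so a drop is the natural expectation. Against this, the chain of compound 4 is longer than that of compound 1, and the lengthening step a number 0.40 log units lower from compound 2 to compound 3 (beyond the scatter) shows that a longer chain went with a higher number in this set. Weighing the two, compound 4 is expected to fall below compound 3 by a number 0.50 log units lower from compound 3 to compound 4 (beyond the scatter), a modest step beyond the scatter. The estimate for compound 4 in this assay is 6.1, with a range from 5.6 to 6.6.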

Compound 4, negative logarithm of the antagonist equilibrium constant: 5.7
Compound 4: the middle estimate sits 0.40 log units above what was measured, within the range that was stated.
By their numbers in this assay, from the lowest: compounds 4 and 1 (each within the scatter of the next); then compound 3; then compound 2.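

In this assay, lengthening the acid chain, with 2-carboxyethyl in place of carboxy, gives a number 0.10 log units lower from compound 1 to compound 4 (within the scatter), whereas the two tetrazoles differ by a number 0.40 log units lower from compound 2 to compound 3 (beyond the scatter), so the link between a longer chain and a higher number holds only for compound 2 and compound 3, and the pair of acids, compound 1 and compound 4, goes against it. The tetrazole carries the higher number against this longer acid too, with carboxymethyl in place of 2H-tetrazol-5-yl giving a number 0.90 log units lower from compound 3 to compound 4 (beyond the scatter) and carboxy in place of (2H-tetrazol-5-yl)methyl giving a number 1.30 log units lower from compound 2 to compound 4 (beyond the scatter). The gain from the tetrazole is also not a fixed amount, since it differs with the chain that carries it: the same change on two cores in this assay, a number 0.80 log units higher (beyond the scatter) from compound 1 to compound 3 and a number 1.30 log units higher (beyond the scatter) from compound 4 to compound 2, 0.50 log units apart, beyond the scatter of two such steps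

The compounds shown leave open whether a tetrazole on a chain longer than that of compound 2 would carry the number further or whether it would fall back. They also leave open whether a carboxylic acid on a still longer chain would stay level with compound 1 and compound 4, and they do not say why the two series respond differently to chain length.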